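Solubility notes on the shared core: compound 1 to compound 3

The source may hold more compounds than are shown below. What is called first, only, known or untested is meant among the compounds shown, and "the series" means these compounds.

Measured so far:
- compound 1, `Cc1cc(C)c(CN2CCc3c(Cl)cc([C@@H](CO)[C@@H]4CCOC4)c(Cl)c3C2=O)c(=O)[nH]1`: 537000 nM
- compound 2, `COc1cc(C)[nH]c(=O)c1CN1CCc2c(Cl)cc([C@H](O)C3COC3)c(Cl)c2C1=O`: 234000 nM

Both compounds were run in a physicochemical assay for solubility, measured as kinetic solubility; on this read-out higher numbers stand for higher solubility and lower numbers for lower solubility. Among the two numbers, compound 1 stands highest, giving 537000 nM in this assay. Its nearest neighbour is compound 2, whose value of 234000 nM sits lower by a gap that is beyond the usual scatter. The two differ in several places at once, so no single-point step can be read from that pair.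

Compound 3, `Cc1cc(C)c(CN2CCc3c(Cl)cc([C@H](C)CO)c(Cl)c3C2=O)c(=O)[nH]1`, has not yet been measured. It differs from compound 1 in one place: methyl in place of oxolan-3-yl on a saturated chain carbon bound to an aromatic carbon and a saturated chain carbon. The oxolan-3-yl group carries the only hydrogen-bond acceptor of the part that leaves, and methyl brings none; the rest of the core is unchanged.

With no measured step of this kind in the series, the expectation is a small downward move, (a 1.3-fold lower number from compound 1 to compound 3 (0.13 log units; within the scatter)), likely within the scatter of repeated measurements. Compound 3 is accordingly estimated at 400000 nM in this assay, with a range from 150000 nM to 900000 nM.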

Compound 3, solubility: 131000 nM
Beside the measured number, compound 3's estimate is 3.1-fold (0.48 log units) above it; measured number outside the range, below it.
By their numbers in this assay, from the lowest: compounds 3 and 2 (each within the scatter of the next); then compound 1.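

On the saturated chain carbon bound to an aromatic carbon and a saturated chain carbon, the series now has a single-place step that can be read: in this assay, methyl in place of oxolan-3-yl gives a 4.1-fold lower number from compound 1 to compound 3 (0.61 log units; beyond the scatter). Compound 1 and compound 2 differ in several places and could not isolate this position, whereas here the read-out is seen to respond to the group at this one carbon, with everything else in the core held constant. The change removes a five-membered non-aromatic ring with 1 hetero atom, 1 hydrogen-bond acceptor and 1 defined stereocentre, but no measurement at hand bears on why the number moves, so the step stands as an observation on this one pair.

This single step changes the ring, its oxygen and the size of the group together, so their shares cannot be separated; a cyclopentyl group on this carbon would keep the ring without the oxygen. Going by these compounds, how the read-out would respond here to an amine such as dimethylamino, a carboxylic acid or a longer chain such as propyl remains open, as does whether a step of this size carries over to other members.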